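The compounds below may be only part of what the source reports. "The series", "measured", "known", "first", "only" and "open" are said of these compounds alone.

Working notes on the series.

Three compounds have numbers in a functional assay on the whole organism (Tail, strain ICR) with Mus musculus as the target, in the tail flick test, with a stated time of 60 min, at a dose of 25 umol/kg by the oral route; on this read-out higher numbers stand for a stronger effect at the one dose given and lower numbers for a weaker effect. Compound 1 `N=C(N)NCCC[C@H](NC(=O)CN(c1nc(Cl)nc2[nH]cnc12)C1CC1)C(=O)OCc1ccccc1` gives 30.6%. Compound 2 `O=C(OCc1ccccc1)[C@@H]1CCCN1C(=O)CN(c1nc(Cl)nc2[nH]cnc12)C1CC1` gives 34.4%, and compound 3 `O=C(CN(c1ncnc2c1ncn2C1CCCCO1)C1CC1)N[C@@H](CCC(=O)OCc1ccccc1)C(=O)OCc1ccccc1` gives 34.7%. Compound 1 stands at the low end of these three figures, but both other numbers lie within the usual scatter of its own, so the three are not separated by this assay. Going by the values given here, no pair among them differs in a single place, and no step between measured compounds is available.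

Compound 4 `C[C@@H](O)[C@H](NC(=O)CN(c1nc(Cl)nc2[nH]cnc12)C1CC1)C(=O)OCc1ccccc1` is the next compound to be run in this assay. It differs from compound 1 as follows: a group of 3 heavy atoms (2 carbon, 1 oxygen; no ring) in place of a group of 7 heavy atoms (4 carbon, 3 nitrogen; no ring), on a saturated chain carbon bound to an amide-type nitrogen and a carbonyl carbon. Among the compounds with values here, since no measured step covers a change of this kind, the expectation rests on the shared core and on the spread of the three numbers already in hand. The step from compound 1 to compound 4 is expected to be small, a number 3.6 percentage points lower from compound 1 to compound 4 (within the scatter), not clearly beyond the scatter, with a slight lean downward. Compound 4 is accordingly estimated at 27% in this assay, within a range from 14% to 40%.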

Compound 4, a percentage reported as activity, at one dose (the size of the read-out at that dose, not a potency): 29.7%
The estimate for compound 4 lay 2.7 percentage points below the measured number, within the range that was stated.
By their numbers in this assay, from the lowest: compounds 4, 1, 2 and 3 (each within the scatter of the next).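

In this assay, compound 4 provides the first step read at this position (a number 0.9 percentage points lower from compound 1 to compound 4 (within the scatter)). On the saturated chain carbon bound to an amide-type nitrogen and a carbonyl carbon, 1-hydroxyethyl in place of the group of 7 heavy atoms (4 carbon, 3 nitrogen; no ring) therefore gives a difference that this read-out does not separate from scatter, even though the entering group is much smaller and carries fewer hydrogen-bond donors. No supporting data bear on this result, so it stays an observation without an assigned cause.

As far as these compounds go, whether an amine, a carboxylic acid or a longer chain at this carbon would move the number beyond the scatter remains open. The compounds shown also leave open whether the other configuration of the 1-hydroxyethyl stereocentre would read differently.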